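One Added Methyl at Two Different Chain Positions

The source may report more compounds than this note shows. Statements on the series, on what has been measured and on what is new or still open speak of the compounds shown alone.

Compound 1 `CCc1onc(-c2ccc(Cl)cc2)c1COc1ccc(CCC(=O)O)c(C)c1C` and compound 2 `CCCc1onc(-c2ccc(Cl)cc2)c1COc1ccc(CCC(=O)O)c(C)c1C` share one core, whereas compound 3 `Cc1ccc(-c2noc(C(F)(F)F)c2COc2c(F)cc(CCC(=O)O)cc2F)cc1` rests on another; the difference between the two cores is not broken down here. In an ADME assay on microsomes from liver (Homo sapiens) for metabolic stability, with a stated time of 10 min (a lower number here means that less of the compound is left, a higher number that more of the compound is left), compound 1 gives 66.3% and compound 2 gives 79.3%. The change between them, (methyl in place of hydrogen on a saturated chain carbon, two bonds along the chain from an aromatic carbon), produced a number 13 percentage points higher from compound 1 to compound 2 (beyond the scatter). In this assay compound 3 gives 64.4%. Compound 4 `Cc1ccc(-c2noc(C(F)(F)F)c2COc2c(F)cc(CC(C)C(=O)O)cc2F)cc1` awaits measurement and differs from compound 3 by methyl in place of hydrogen on a saturated chain carbon bound to a carbonyl carbon and a saturated chain carbon. This is the same kind of change as that between compound 1 and compound 2, but not the same: there the methyl entered two bonds along the chain from an aromatic carbon, here on a saturated chain carbon bound to a carbonyl carbon and a saturated chain carbon. Going by the values given here, because the one measured instance gave a number 13 percentage points higher from compound 1 to compound 2 (beyond the scatter), a smaller step of a number 5.6 percentage points higher from compound 3 to compound 4 (within the scatter) is expected in this assay, tempered by the different place. Compound 4 is thus estimated at 70%, between 52% and 86%.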

Compound 4, percent of the compound remaining: 93%
The estimate for compound 4 lay 23 percentage points below the measured number; the whole stated range lies below it.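

In this assay the added methyl gave a number 28.6 percentage points higher from compound 3 to compound 4 (beyond the scatter), so the direction of the earlier step held, but its size did not carry over from one core to the other: the same change on two cores in this assay, a number 13 percentage points higher (beyond the scatter) from compound 1 to compound 2 and a number 28.6 percentage points higher (beyond the scatter) from compound 3 to compound 4, 15.6 percentage points apart, beyond the scatter of two such steps. The two steps differ in core and in place at once, the methyl entering two bonds along the chain from an aromatic carbon in one and on a saturated chain carbon bound to a carbonyl carbon and a saturated chain carbon in the other. These two pairs therefore cannot show whether the core, the place or both set the size of the step.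

The compounds shown leave open what the same change on the 2-carboxyethyl chain would give on the core of compound 1. They also leave open how an ethyl group in place of the new methyl would read.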